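The source may hold more compounds than are shown below. What is called first, only, known or untested is meant among the compounds shown, and "the series" means these compounds.

Measured so far:
Compound 1, `O=C(/C=C/c1ccc(/C=N/NC(=O)c2ccncc2)cc1)c1cccc(Br)c1`: 14%
Compound 2, `Cc1ccc(C(=O)/C=C/c2ccc(/C=N/NC(=N)N)cc2)cc1`: 77.7%

Both numbers come from a functional assay on the whole organism (Ear) for inhibition, with Mus musculus as the target, with a stated time of 30 min, at a dose of 100 mg/kg by the intraperitoneal route; on this read-out lower numbers stand for less inhibition and higher numbers for more inhibition at the one dose given (going by the name of the read-out). Compound 2 holds the higher of the two numbers; compound 1 lies lower by more than the usual scatter. Compound 3, `N=C(N)N/N=C/c1ccc(/C=C/C(=O)c2cccc(Cl)c2)cc1`, differs from compound 2 in one place: 3-chlorophenyl in place of 4-methylphenyl on a carbonyl carbon. Among the compounds with values here, no pair of measured compounds differs in a single place, so there is no step of this kind to lean on. Swapping one six-membered aromatic ring of carbon only for another on the carbonyl carbon is expected to move the number little, probably not beyond the scatter. Compound 3 is expected to give 65%, with a range from 40% to 85%. The expected step is a number 12.7 percentage points lower from compound 2 to compound 3 (beyond the scatter), a slight decrease.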

Compound 3, a percentage reported as inhibition, in the whole organism at one dose (the size of the read-out at that dose, not a potency): 80.7%
Compound 3: middle estimate off by 15.7 percentage points, on the low side; low and high end bracket the measured number.
By their numbers in this assay, from the lowest: compound 1; then compounds 2 and 3 (each within the scatter of the next).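

In this assay, 3-chlorophenyl in place of 4-methylphenyl on a carbonyl carbon gives a number 3 percentage points higher from compound 2 to compound 3 (within the scatter) and so leaves the read-out unchanged within the scatter. Within the data shown here, this is the first pair that differs in one place, and it shows that this position can carry either of these two substituted aromatic rings at this dose. No measurement on hand accounts for this result.

Still open, from the compounds shown here alone, is how an unsubstituted phenyl would read here. So is whether a non-aromatic group, such as an amine or a carboxylic acid, would serve on this carbonyl carbon.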